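The compounds below may be only part of what the source reports. "The series", "measured", "known", "first", "only" and "open" are said of these compounds alone.

Measured so far:
compound 1, `CC1(C)c2cc(Cl)ccc2C(=O)N1c1cncc(OC2CN(C(=O)c3ncccc3Cl)C2)c1`: 5 nM
compound 2, `Cn1cc(C(=O)N2CC3(C2)CN(c2cncc(N4C(=O)c5ccc(Cl)cc5C4(C)C)c2)C3)cn1`: 2 nM

In an assay on cells for inhibition of cytochrome P450 11B2, mitochondrial (Homo sapiens), read by HTRF (on this read-out lower numbers stand for stronger inhibition and higher numbers for weaker inhibition), compound 1 gives 5 nM, the higher of the two numbers recorded. Compound 2 gives 2 nM, a lower number, and the gap between the two lies beyond the usual scatter of this assay. Going by the values given here, the two compounds differ in more than one place, so their values show only that the pair sits close together at the potent end.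

Compound 3, `Cn1cc(C(=O)N2CC(Oc3cncc(N4C(=O)c5ccc(Cl)cc5C4(C)C)c3)C2)cn1`, is built from compound 1 by one change: 1-methyl-1H-pyrazol-4-yl in place of 3-chloropyridin-2-yl on a carbonyl carbon. Among the compounds with values here, the same 1-methyl-1H-pyrazol-4-yl carbonyl group is present in compound 2, but no measured pair isolates this single change, so no step for it is known. On the two values at hand, compound 3 is expected to land near compound 1, with at most a small step downward and possibly none beyond the scatter. Compound 3 is estimated at 3 nM in this assay, within a range of 1 nM to 10 nM. This estimate corresponds to an expected step of a 1.7-fold lower number from compound 1 to compound 3 (0.22 log units; within the scatter).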

Compound 3, half-maximal inhibitory concentration in the cytochrome P450 11B2, mitochondrial assay: 0.5 nM
Beside the measured number, compound 3's estimate is 6.0-fold (0.78 log units) above it; the measured number lies below the stated range.
By their numbers in the cytochrome P450 11B2, mitochondrial assay, from the lowest: compound 3; then compound 2; then compound 1.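

In the cytochrome P450 11B2, mitochondrial assay, the group on this carbonyl carbon now has a measured effect of its own: 1-methyl-1H-pyrazol-4-yl in place of 3-chloropyridin-2-yl gives a 10-fold lower number from compound 1 to compound 3 (1.00 log units; beyond the scatter) on an otherwise unchanged structure. The earlier pair of compounds differed in more than one place and could not isolate this step. The stronger inhibition also comes with no loss in a physicochemical assay for solubility, in phosphate buffer, with a stated time of 2 h, at pH 6.5 (on this read-out lower numbers stand for lower solubility and higher numbers for higher solubility), where the same change raises the number: the measured solubility of compound 1, 20 ug/mL, and of compound 3, 310 ug/mL, a 16-fold higher number (1.19 log units; beyond the scatter). In the physicochemical assay compound 1 gives 20 ug/mL and compound 3 gives 310 ug/mL.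

As far as these compounds go, this result rests on a single pair, so it remains open whether the step would carry over to other cores, including that of compound 2. Also open, from the compounds shown here alone, is how an open-chain amine or a morpholine ring on the same carbonyl carbon would compare on both read-outs.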